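From a Saturated Ring to an Aromatic One at the Amine

The source may hold more compounds than are shown below. What is called first, only, known or untested is meant among the compounds shown, and "the series" means these compounds.

Compound 1 `COc1cc(N)c(Cl)cc1NC(=O)C1CCN(CC2CC2)CC1` carries cyclopropyl on a saturated chain carbon bound to an amine nitrogen in a ring. In a functional assay on the whole organism for antagonist activity, with Mus musculus as the target (a lower number here means that less compound is needed, a higher number that more compound is needed for the effect), compound 1 reaches only a limit, > 10 mg/kg. Compound 2 `COc1cc(N)c(Cl)cc1NC(=O)C1CCN(CC2CCCCCC2)CC1` carries cycloheptyl in the same place. In this assay compound 2 likewise stops at a limit, > 10 mg/kg, sitting at the limit of > 10 mg/kg in this assay, at which 2 of the 3 values shown sit. Compound 3 `COc1cc(N)c(Cl)cc1NC(=O)C1CCN(Cc2ccccc2)CC1` carries phenyl there and gives 0.5 mg/kg in this assay. The step of an at least 20-fold lower number from compound 2 to compound 3 (1.30 log units; beyond the scatter) is the one that bears on the question, while a step that the two limits leave unreadable from compound 1 to compound 2 adds nothing. Compound 4 `CCOc1ccc(CN2CCC(C(=O)Nc3cc(Cl)c(N)cc3OC)CC2)cc1` is not yet measured and differs from compound 2 by 4-ethoxyphenyl in place of cycloheptyl on a saturated chain carbon bound to an amine nitrogen in a ring. Because compound 3 brought an at least 20-fold lower number from compound 2 to compound 3 (1.30 log units; beyond the scatter), compound 4 is expected to show a similar large fall, an at least 16-fold lower number from compound 2 to compound 4 (1.22 log units; beyond the scatter). Compound 4 is therefore estimated at 0.6 mg/kg, between 0.15 mg/kg and 2.5 mg/kg.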

Compound 4, dose for half-maximal effect: 6.3 mg/kg
The estimate for compound 4 lay 11-fold (1.02 log units) below the measured number; measured number above the stated range.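

In this assay, the phenyl group at this place does not keep its result once it is substituted: ethoxy in place of hydrogen on an aromatic carbon gives a 13-fold higher number from compound 3 to compound 4 (1.10 log units; beyond the scatter). An aromatic ring here is thus not enough on its own, as 4-ethoxyphenyl gives only an at least 1.5-fold lower number from compound 2 to compound 4 (0.20 log units; that floor lies within the scatter) and an at least 1.5-fold lower number from compound 1 to compound 4 (0.20 log units; that floor lies within the scatter). Both of these steps start from a limit, not a number: the limit of > 10 mg/kg in this assay, at which 2 of the 4 values shown sit.

The compounds shown leave open whether methoxy or hydroxyl in place of that hydrogen would behave like ethoxy. They also leave open how a longer chain in place of ethoxy would read.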